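Amide cap variation in a GIPR inhibitor series

The source may report more compounds than this note shows. Statements on the series, on what has been measured and on what is new or still open speak of the compounds shown alone.

Measured so far:
compound 1 `Cc1nc(S(C)(=O)=O)ccc1Oc1ncnc(OC2CCN(C(=O)SC3CC3)CC2)c1F` — 24.9 nM
compound 2 `CCC(F)(F)C(=O)N1CCC(Oc2ncnc(Oc3ccc(S(C)(=O)=O)nc3C)c2F)CC1` — 17.4 nM

In a functional assay on isolated protein for inhibition of Glucose-dependent insulinotropic receptor (Homo sapiens), read by HTRF and cAMP accumulation (a lower number here means that less compound is needed, a higher number that more compound is needed for the effect), compound 2 gives 17.4 nM, and compound 1 gives 24.9 nM; the two lie within the scatter of each other, so neither stands apart. Among the measured compounds shown here, the only step so far, a 1.4-fold lower number from compound 1 to compound 2 (0.16 log units; within the scatter), shows that replacing one cap on the carbonyl carbon by another left this assay essentially unmoved.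

Compound 3 `Cc1nc(S(C)(=O)=O)ccc1Oc1ncnc(OC2CCN(C(=O)c3nc(C(C)(C)F)no3)CC2)c1F` differs from compound 2 by a group of 9 heavy atoms (5 carbon, 2 nitrogen, 1 oxygen, 1 fluorine; one five-membered aromatic ring with 3 hetero atoms) in place of a group of 5 heavy atoms (3 carbon, 2 fluorine; no ring), on a carbonyl carbon. For the measured compounds named here, the one step that bears on this place was small, so for compound 3 no step beyond the scatter is expected in this assay: the estimated change is a 1.3-fold higher number from compound 2 to compound 3 (0.10 log units; within the scatter). Compound 3 is therefore expected to give about 22 nM, within a range of 7 nM to 70 nM.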

Compound 3, half-maximal effective concentration: 43.4 nM
Estimate against measurement, compound 3: 2.0-fold (0.30 log units) below, within the range that was stated.
By their numbers in this assay, from the lowest: compounds 2, 1 and 3 (each within the scatter of the next, the first and the last beyond it).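

In this assay, among the compounds shown here, the five-membered aromatic cap gives the first step at this position beyond the scatter, a 2.5-fold higher number from compound 2 to compound 3 (0.40 log units; beyond the scatter), so the carbonyl carbon's substituent is not wholly silent. The picture depends on the comparison, however: a 1.7-fold higher number from compound 1 to compound 3 (0.24 log units; within the scatter), stays within the scatter, so the new cap separates clearly from only one of the two earlier caps. No measurement available here accounts for this result. Still open, going by these compounds, is whether the shift follows the aromatic ring itself or its fluorinated substituent. A methyl group on the same ring, or a dimethylamino cap on the carbonyl carbon, would bear on this.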